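Aromatic-nitrogen substituent swap: expected read-out for compound 4

The source may hold more compounds than are shown below. What is called first, only, known or untested is meant among the compounds shown, and "the series" means these compounds.

Measured in an assay on BTI cells for inhibition of Amine oxidase [flavin-containing] B (Homo sapiens), read by fluorescence, with stated times of 30 min and 1 h, tested at 1 uM; a lower number here means less inhibition, a higher number more inhibition at the concentration tested (going by the name of the read-out):
compound 1 `C[C@H](NCc1ccc(OCCCCCN2CCN(c3cccc4c3ccn4Cc3cccc(Cl)c3)CC2)cc1)C(N)=O`: 43%
compound 2 `C[C@H](NCc1ccc(OCCCCCN2CCN(c3cccc4c3ccn4S(=O)(=O)c3ccccc3)CC2)cc1)C(N)=O`: 17%
compound 3 `C#CCN(C)Cc1ccc(OCCCCN2CCN(c3cccc4c3ccn4Cc3cccc(Cl)c3)CC2)cc1`: 85%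

Compound 1 and compound 2 share a core and differ by phenylsulfonyl in place of 3-chlorobenzyl on an aromatic nitrogen. This change gives a number 26 percentage points lower from compound 1 to compound 2 (beyond the scatter) in this assay. Compound 3 carries a different core; how the two cores differ is not broken down here. Compound 3 stands highest of the three, with both steps to the others beyond the scatter.

Compound 4 `C#CCN(C)Cc1ccc(OCCCCN2CCN(c3cccc4c3ccn4S(=O)(=O)c3ccccc3)CC2)cc1` is not yet measured in this assay. It differs from compound 3 by phenylsulfonyl in place of 3-chlorobenzyl on an aromatic nitrogen, the same change, at the same place, as that from compound 1 to compound 2. The expectation for compound 4 is a lowering of the same kind, estimated as a number 27 percentage points lower from compound 3 to compound 4 (beyond the scatter), because the earlier instance gave a number 26 percentage points lower from compound 1 to compound 2 (beyond the scatter) and compound 3 starts from 85%. Compound 4 is therefore estimated at 58% in this assay, with a range from 38% to 78%.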

Compound 4, a percentage reported as inhibition, at one concentration (the size of the read-out at that concentration, not a potency): 51%
For compound 4 the middle estimate is 7 percentage points above the measured one; low and high end bracket the measured number.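

In this assay, phenylsulfonyl in place of 3-chlorobenzyl on an aromatic nitrogen again lowers the read-out, with a number 34 percentage points lower from compound 3 to compound 4 (beyond the scatter). Set beside the earlier instance, the change carries over to the second core with a size that cannot be told apart from the first: the same change on two cores in this assay, a number 26 percentage points lower (beyond the scatter) from compound 1 to compound 2 and a number 34 percentage points lower (beyond the scatter) from compound 3 to compound 4, 8 percentage points apart, within the scatter of two such steps. This is agreement across two pairs at one tested concentration, so it shows neither a rule for other cores nor a potency shift, and it does not tell which difference between the two groups accounts for the lowering.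

The compounds shown carry only these two groups on the aromatic nitrogen, so it remains open where an unsubstituted nitrogen, a methyl or a plain benzyl would fall relative to them. As far as these compounds go, a 3-chlorophenylsulfonyl group also remains open, as it would show whether the chlorine or the sulfonyl link goes with the difference.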